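Dropping the benzyloxy group: expected cytotoxicity of compound 4

The compounds below may be only part of what the source reports. "The series", "measured", "known", "first", "only" and "open" are said of these compounds alone.

Compound 3 `Cc1ccccc1C1CC(c2ccc(OCc3ccccc3)cc2)=NN1c1ccc(S(N)(=O)=O)cc1` stands at the top of the numbers seen so far. In an ADME assay on MT4 cells (Homo sapiens) for cytotoxicity, read by MTT assay, with a stated time of 96 h (on this read-out lower numbers stand for higher toxicity in this test and higher numbers for lower toxicity in this test), compound 3 gives >= 100000 nM, which is a limit of the assay rather than a number. Compound 1 `Cc1ccccc1C1CC(c2ccc(Oc3ccccc3)cc2)=NN1c1ccc(S(N)(=O)=O)cc1` gives 36000 nM in this assay, and compound 2 `NS(=O)(=O)c1ccc(N2N=C(c3ccccc3)CC2c2ccccc2Cl)cc1` gives 44000 nM. For the measured compounds named here, the one measured step that bears on the change is an at least 2.7-fold higher number from compound 1 to compound 3 (0.44 log units; beyond the scatter), which ends at the limit of >= 100000 nM in this assay, at which 1 of the 3 values shown sits. Compound 4 `Cc1ccccc1C1CC(c2ccccc2)=NN1c1ccc(S(N)(=O)=O)cc1` differs from compound 3 by hydrogen in place of benzyloxy on an aromatic carbon. Going by the values given here, no measured step removes this group outright, so the expectation leans on compounds 1 and 2 and on the limit of compound 3. Compound 4 is expected to give 60000 nM in this assay, between 30000 nM and 150000 nM, an estimated step of an at least 1.6-fold lower number from compound 3 to compound 4 (0.22 log units; that floor lies within the scatter).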

Compound 4, half-maximal cytotoxic concentration: 43000 nM
Estimate against measurement, compound 4: 1.4-fold (0.14 log units) above, and the stated range covers the measured number.
By their numbers in this assay, from the lowest: compounds 1, 4 and 2 (each within the scatter of the next). At a limit, above all of these: compound 3.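

Hydrogen in place of benzyloxy gives an at least 2.3-fold lower number from compound 3 to compound 4 (0.36 log units; beyond the scatter) in this assay, so among these compounds only benzyloxy at this place stands apart. Compound 3 sits at a limit, so the full size of this step stays unknown: the limit of >= 100000 nM in this assay, at which 1 of the 4 values shown sits.

Phenoxy at the same place does not stand apart from hydrogen, with a 1.2-fold higher number from compound 1 to compound 4 (0.08 log units; within the scatter), and chloro and methyl do not stand apart from each other, with a 1.0-fold lower number from compound 2 to compound 4 (0.01 log units; within the scatter). The compounds shown leave open whether an amine, a carboxylic acid or a longer chain ending in phenyl at this place would follow benzyloxy or phenoxy.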